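This account rests on a few compounds, and the source may have more. Where it says the series, first, only, none or still open, it means among the compounds named here.

Working notes on the series. Within the data shown here, in a functional assay on BGC-823 cells (Homo sapiens) for antiproliferative activity, read by MTT assay, tested at 5 uM (on this read-out higher numbers stand for a stronger effect at the one concentration tested and lower numbers for a weaker effect), compound 3 `COc1cc(C2=NN(C(C)=O)C(c3cccc(F)c3)O2)cc(OC)c1OC` gives 37.7% and stands highest of the three numbers so far: compound 1 `COc1cc(C2=NN(C(C)=O)C(c3cc(Cl)cc(Cl)c3)O2)cc(OC)c1OC` gives 6.6% and compound 2 `COc1ccc(C2OC(c3cc(OC)c(OC)c(OC)c3)=NN2C(C)=O)c(OC)c1` gives -3.1%. Both steps onto compound 3 are large, a number 31.1 percentage points higher from compound 1 to compound 3 (beyond the scatter) and a number 40.8 percentage points higher from compound 2 to compound 3 (beyond the scatter), whereas a number 9.7 percentage points lower from compound 1 to compound 2 (within the scatter). Compound 4 `COc1cc(C2=NN(C(C)=O)C(c3cccc(C(F)(F)F)c3)O2)cc(OC)c1OC` differs from compound 3 by trifluoromethyl in place of fluoro on an aromatic carbon. Among the measured compounds shown here, no measured step exchanges fluoro for trifluoromethyl; the two steps onto compound 3 only show that the group on the saturated ring carbon governs the read-out. For the measured compounds named here, with no direct precedent, the expectation for compound 4 is a moderate loss, a number 12.7 percentage points lower from compound 3 to compound 4 (beyond the scatter), the direction uncertain. Compound 4 is therefore estimated at 25%, in the range 0% to 50%.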

Compound 4, a percentage reported as inhibition, at one concentration (the size of the read-out at that concentration, not a potency): 41.1%
The estimate for compound 4 lay 16.1 percentage points below the measured number, and the stated range covers the measured number.
By their numbers in this assay, from the lowest: compounds 2 and 1 (each within the scatter of the next); then compounds 3 and 4 (each within the scatter of the next).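

In this assay, trifluoromethyl is accepted in place of fluoro on this aromatic carbon, with no change beyond the scatter (a number 3.4 percentage points higher from compound 3 to compound 4 (within the scatter)). Among these compounds, the high read-out is therefore not confined to the single fluoro group, as 3-(trifluoromethyl)phenyl also keeps large steps over the other two groups on the saturated ring carbon (a number 34.5 percentage points higher from compound 1 to compound 4 (beyond the scatter)) and (a number 44.2 percentage points higher from compound 2 to compound 4 (beyond the scatter)). No measured evidence bears on why these two groups read alike. Going by these compounds, whether an amine or a carboxylic acid on the same aromatic carbon would hold this read-out remains open.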